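A few compounds are considered here, and "the series" means these few. Any claim that something is new, unique, unknown or untested is made for them only; others in the source may bear on it.

Compound 3 `CC(NC(=O)C#Cc1ccc(NC(=O)Nc2ccc(Cl)c(C(F)(F)F)c2)cc1)c1ccccc1` and compound 1 `CC(NC(=O)C#Cc1ccc(NC(=O)Nc2cc(C(F)(F)F)ccc2Cl)cc1)c1ccccc1` share a core and differ in one place: 2-chloro-5-(trifluoromethyl)phenyl in place of 4-chloro-3-(trifluoromethyl)phenyl on an amide-type nitrogen. In a functional assay on MX1 cells (Homo sapiens) for inhibition, read by MTT assay, with a stated time of 120 h (on this read-out lower numbers stand for stronger inhibition and higher numbers for weaker inhibition), compound 3 gives 12800 nM, and compound 1 gives 16100 nM, so the change made a 1.3-fold higher number from compound 3 to compound 1 (0.10 log units; within the scatter). Compound 2 `CC(NC(=O)/C=C/c1ccc(NC(=O)Nc2ccc(Cl)c(C(F)(F)F)c2)cc1)c1ccccc1` has a different core; how its core differs from that of compound 3 is not broken down here. In this assay compound 2 gives 3130 nM, the lowest of the three numbers. Compound 4 `CC(NC(=O)/C=C/c1ccc(NC(=O)Nc2cc(C(F)(F)F)ccc2Cl)cc1)c1ccccc1` is reached from compound 2 by the same change: 2-chloro-5-(trifluoromethyl)phenyl in place of 4-chloro-3-(trifluoromethyl)phenyl on an amide-type nitrogen. Because the earlier change gave a 1.3-fold higher number from compound 3 to compound 1 (0.10 log units; within the scatter), a small step is expected, a 1.3-fold higher number from compound 2 to compound 4 (0.11 log units; within the scatter), from compound 2 to compound 4. Compound 4 is therefore estimated at 4000 nM in this assay, most likely between 2000 nM and 9000 nM.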

Compound 4, half-maximal inhibitory concentration: 1890 nM
Compound 4: middle estimate off by 2.1-fold (0.33 log units), on the high side; measured number below the stated range.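

In this assay, putting 2-chloro-5-(trifluoromethyl)phenyl in place of 4-chloro-3-(trifluoromethyl)phenyl on the amide-type nitrogen gave a 1.7-fold lower number from compound 2 to compound 4 (0.22 log units; within the scatter). Set beside the earlier step, the result on this second core agrees with the first: the same change on two cores in this assay, a 1.3-fold higher number (0.10 log units; within the scatter) from compound 3 to compound 1 and a 1.7-fold lower number (0.22 log units; within the scatter) from compound 2 to compound 4, 2.1-fold (0.32 log units) apart, within the scatter of two such steps So the swap made no step beyond the scatter on either core, but two pairs do not give a rule for other cores, and they cannot show that the core truly changes the effect of the swap.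

All four compounds carry the same chlorine and trifluoromethyl groups on this ring. Going by these compounds, what would happen with another group, such as a methoxy group or a carboxylic acid in place of the chlorine, remains open.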